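The compounds below may be only part of what the source reports. "The series", "measured", "known", "first", "only" and "open" are said of these compounds alone.

Compound 3 `CCOC(=O)C(Cn1ccnc1)NC(=O)c1c(C)nn(-c2ccccc2)c1Cl` was tested in an assay on HL-60 cells for inhibition of cytochrome P450 26A1 (Homo sapiens), read by HPLC, using microsomes and NADPH, with a stated time of 30 min (on this read-out lower numbers stand for stronger inhibition and higher numbers for weaker inhibition), where compound 3 gives 600 nM. Two other compounds share the ester and imidazole-bearing side chain on a different acyl part: compound 1 `COC(=O)C(Cn1ccnc1)NC(=O)c1ccc(-c2ccccc2)cc1`, which in this assay gives 370 nM, and compound 2 `CC(C)OC(=O)C(Cn1ccnc1)NC(=O)c1ccc(-c2ccccc2)cc1`, which in this assay gives 540 nM. Compound 3 stands with these two, all three numbers lying within the usual scatter of one another, so no order among them can be read.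

Compound 4 `CCCOC(=O)C(Cn1ccnc1)NC(=O)c1c(C)nn(-c2ccccc2)c1Cl` differs from compound 3 by methyl in place of hydrogen on a saturated chain carbon, two bonds along the chain from an oxygen next to a carbonyl group. Among the measured compounds shown here, the only measured step that bears on this change is the one in the ester alkyl group, a 1.5-fold higher number from compound 1 to compound 2 (0.16 log units; within the scatter), which was within the scatter. Nothing in the data points to a change beyond the scatter when the ester alkyl grows by one carbon, so the step to compound 4 in this assay is expected to be no change at the digits printed from compound 3 to compound 4 (within the scatter). Compound 4 is therefore expected to give about 600 nM in this assay, with a range of 300 nM to 1200 nM.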

Compound 4, half-maximal inhibitory concentration: 620 nM
For compound 4 the middle estimate is 1.0-fold (0.01 log units) below the measured one; the measured number falls inside the stated range.
By their numbers in this assay, from the lowest: compounds 1, 2, 3 and 4 (each within the scatter of the next).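

In this assay, the ethoxy to propoxy change on the ester of compound 3 gives a 1.0-fold higher number from compound 3 to compound 4 (0.01 log units; within the scatter) and so stays within the scatter. Among the compounds shown here, until now the only ester step available was the branched one on the other acyl part, a 1.5-fold higher number from compound 1 to compound 2 (0.16 log units; within the scatter) there, so this result adds a straight-chain extension on the second acyl part, which also produces no readable change. Nothing given here accounts for this result.

Going by these compounds, whether a longer chain such as butyl, a benzyl ester or a carboxylic acid in place of the ester would also stay within the scatter remains open. No two compounds shown carry the same ester on both acyl parts, so the effect of the acyl part itself cannot be read.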